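Two difluorophenyl isomers and a cytotoxicity limit

A few compounds are considered here, and "the series" means these few. Any claim that something is new, unique, unknown or untested is made for them only; others in the source may bear on it.

Compound 1 `CCOC(=O)c1cc(-c2cccc(OCc3cccc(C#N)c3)c2)on1`: in an ADME assay on Vero cells (Chlorocebus sabaeus) for cytotoxicity, with a stated time of 72 h (on this read-out higher numbers stand for weaker inhibition and lower numbers for stronger inhibition), compound 1 gives only a limit, > 128000 nM.
Compound 2 `CCOC(=O)c1cc(-c2cccc(OCc3ccc(F)c(F)c3)c2)on1`: in this assay compound 2 gives only a limit, > 128000 nM.

Among the measured compounds shown here, compound 2 thus stands at a limit, and the one other value shown is a limit as well. The change to compound 3 `CCOC(=O)c1cc(-c2cccc(OCc3c(F)cccc3F)c2)on1` is 2,6-difluorophenyl in place of 3,4-difluorophenyl on a saturated chain carbon bound to an oxygen on an aromatic ring. For the measured compounds named here, the only measured step, a step that the two limits leave unreadable from compound 1 to compound 2, cannot be sized, since both ends sit at the limit of > 128000 nM in this assay, at which 2 of the 2 values shown sit. No readable step bears on the change, so no shift beyond the scatter is expected in this assay for compound 3, and its step that the limit leaves unreadable from compound 2 to compound 3 is expected to be flat. Compound 3 is estimated at 150000 nM, between 60000 nM and 400000 nM, most likely again a limit.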

Compound 3, half-maximal inhibitory concentration: > 128000 nM
Compound 3 ended at the assay's limit; the forecaster's own chance of this, stated with the estimate: 85%; the middle value is on the limit's open side.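

No new step can be read between compound 1, compound 2 and compound 3, since all three stay at a limit: the limit of > 128000 nM in this assay, at which 3 of the 3 values shown sit.

The compounds shown leave open whether these three differ at all in this assay.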